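Piperidinyl ether in place of piperazinyl sulfonamide on the shared core

A few compounds are considered here, and "the series" means these few. Any claim that something is new, unique, unknown or untested is made for them only; others in the source may bear on it.

Three compounds of the shared core have been run in an ADME assay on microsomes from liver (Homo sapiens) for metabolic stability, read by LC-MS, tested at 1 uM; on this read-out higher numbers stand for fast clearance and lower numbers for slow clearance. Compound 1 `NCCOc1ccc([C@H]2CC[C@]3(CC2)OOC2(O3)C3CC4CC(C3)CC2C4)cc1` carries a 2-aminoethoxy group; in this assay compound 1 returns only the assay limit, < 7 mL.min-1.g-1. Compound 2 `c1cc([C@H]2CC[C@]3(CC2)OOC2(O3)C3CC4CC(C3)CC2C4)ccc1OCCC1CCNCC1` carries a 2-(piperidin-4-yl)ethoxy group; in this assay compound 2 likewise returns only the limit, < 7 mL.min-1.g-1. Among the compounds with values here, compound 3 `O=S(=O)(c1ccc([C@H]2CC[C@]3(CC2)OOC2(O3)C3CC4CC(C3)CC2C4)cc1)N1CCNCC1` carries a (piperazin-1-yl)sulfonyl group and in this assay gives 16 mL.min-1.g-1, the only number among the three and the highest value shown; the limit of < 7 mL.min-1.g-1 in this assay, at which 2 of the 3 values shown sit, is where the other two sit.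

The steps toward compound 3 are an at least 2.2-fold higher number from compound 1 to compound 3 (0.35 log units; beyond the scatter) and an at least 2.2-fold higher number from compound 2 to compound 3 (0.35 log units; beyond the scatter). The step that the two limits leave unreadable from compound 1 to compound 2 is hidden by the two limits.

Compound 4 `c1cc([C@H]2CC[C@]3(CC2)OOC2(O3)C3CC4CC(C3)CC2C4)ccc1OC1CCNCC1` differs from compound 3 by (piperidin-4-yl)oxy in place of (piperazin-1-yl)sulfonyl on an aromatic carbon. This returns to an ether-linked basic amine like those of compounds 1 and 2, which both sat at the limit. A lower number is therefore expected, about a 2.7-fold lower number from compound 3 to compound 4 (0.43 log units; beyond the scatter) in this assay. For compound 4 in this assay the estimate is 6 mL.min-1.g-1, in the range 3 mL.min-1.g-1 to 12 mL.min-1.g-1, with a fair chance that only the limit is reported.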

Compound 4, intrinsic clearance in microsomes: 15 mL.min-1.g-1
Compound 4: middle estimate off by 2.5-fold (0.40 log units), on the low side, and the stated range ends below it.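

An ether link on this aromatic carbon does not by itself keep the read-out at a limit in this assay: the steps are an at least 2.1-fold higher number from compound 2 to compound 4 (0.33 log units; beyond the scatter) and an at least 2.1-fold higher number from compound 1 to compound 4 (0.33 log units; beyond the scatter). What sits on the oxygen therefore matters here, with piperidin-4-yl reading apart from both 2-(piperidin-4-yl)ethyl and 2-aminoethyl, so the ethers shown do not behave as one group. Against the sulfonamide, the swap gives a 1.1-fold lower number from compound 3 to compound 4 (0.03 log units; within the scatter), and (piperidin-4-yl)oxy and (piperazin-1-yl)sulfonyl cannot be told apart in this assay.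

The compounds shown leave open how the read-out runs with a (piperidin-4-yl)methoxy group on the same oxygen-bearing carbon, which would test the chain on the oxygen one carbon at a time. As far as these compounds go, whether a carboxylic acid on this aromatic carbon reads with compound 4 or with the ethers at the limit also stays open.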